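Dimethylamino for Methyl: A Small Change on a Potent Lead

This account rests on a few compounds, and the source may have more. Where it says the series, first, only, none or still open, it means among the compounds named here.

Compound 1 `N#Cc1cc(-c2nc(C(c3ccc(F)cc3)c3ccc(F)cc3)sc2CC(=O)O)ccc1F` gives 520 nM in an in vitro functional assay on HEK285-7 cells for antagonist activity at prostaglandin D2 receptor 2 (Homo sapiens), read by BRET and beta-arrestin recruitment; a higher number here means a weaker inhibitor, a lower number a stronger inhibitor.
Compound 3 `Cc1cc(-c2nc(C(c3ccc(F)cc3)c3ccc(F)cc3)sc2CC(=O)O)ccn1` gives 53 nM in this assay.
Compound 2 `NS(=O)(=O)c1ccc(-c2nc(C(c3ccc(F)cc3)c3ccc(F)cc3)sc2CC(=O)O)cc1` reaches only a limit of this assay, > 100000 nM, with no number behind it.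

Compound 3 stands lowest of the two numbers shown; its nearest neighbour is compound 1, with a 9.8-fold lower number from compound 1 to compound 3 (0.99 log units; beyond the scatter). Compound 4 `CN(C)c1cc(-c2nc(C(c3ccc(F)cc3)c3ccc(F)cc3)sc2CC(=O)O)ccn1` differs from compound 3 only by dimethylamino in place of methyl on an aromatic carbon. Within the data shown here, no measured step touches this position: the steps on record, an at least 190-fold higher number from compound 1 to compound 2 (2.28 log units; beyond the scatter) and an at least 1800-fold lower number from compound 2 to compound 3 (3.27 log units; beyond the scatter), exchange the whole aromatic group, and only one sits at the limit (the limit of > 100000 nM in this assay, at which 1 of the 3 values shown sits). So the exchange of methyl for dimethylamino is expected to give a step no larger than the scatter, a 1.5-fold higher number from compound 3 to compound 4 (0.18 log units; within the scatter). Compound 4 is therefore estimated at 80 nM, between 25 nM and 260 nM.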

Compound 4, half-maximal inhibitory concentration: > 100000 nM
Compound 4 was reported as a limit; the forecaster's own chance of this, stated with the estimate: 3%; at least 1200-fold (3.09 log units) between middle value and limit.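

In this assay, among these compounds, the earlier steps exchanged the whole aromatic group, whereas changing only methyl to dimethylamino on the aromatic carbon next to the ring nitrogen gives an at least 1800-fold higher number from compound 3 to compound 4 (3.27 log units; beyond the scatter), so this position does not accept every small change. The 2-(dimethylamino)pyridin-4-yl group also compares poorly with 3-cyano-4-fluorophenyl, with an at least 190-fold higher number from compound 1 to compound 4 (2.28 log units; beyond the scatter). Compound 4 gives only a limit, its step to compound 2 cannot be read, and the two compounds share that limit: the limit of > 100000 nM in this assay, at which 2 of the 4 values shown sit.

Going by these compounds, it remains open whether amino, methylamino, methoxy or ethyl at this carbon would stay close to compound 3 or fall away like compound 4.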